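Working notes: phenoxy variation at the ketone end of the series

The compounds below may be only part of what the source reports. "The series", "measured", "known", "first", "only" and "open" are said of these compounds alone.

Measured so far:
- compound 1 `CC(C)[C@H](NC(=O)COc1cccc2ccccc12)C(=O)N[C@@H](CC(=O)O)C(=O)COc1ccc(Oc2ccc(C(F)(F)F)cc2)cc1`; in a functional assay on Jurkat cells (Homo sapiens) (on this read-out higher numbers stand for weaker inhibition and lower numbers for stronger inhibition), compound 1 gives 9300 nM.
- compound 2 `CC(C)[C@H](NC(=O)COc1cccc2ccccc12)C(=O)N[C@@H](CC(=O)O)C(=O)COc1cccc(F)c1`; in this assay compound 2 returns only the assay limit, > 100000 nM.

Compound 2 stands at the edge of what the assay can report: its entry is a limit, not a number, and it sits at the limit of > 100000 nM in this assay, at which 1 of the 2 values shown sits. Compound 1, with its trifluoromethyl-bearing phenoxyphenyl group, is the only one of the two with a measured number. Going by the values given here, the two compounds differ in more than one place, so no single step between them is computed; their values show only that compound 1 has a number and compound 2 does not.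

Compound 3 `CC(C)[C@H](NC(=O)COc1cccc2ccccc12)C(=O)N[C@@H](CC(=O)O)C(=O)COc1ccc([N+](=O)[O-])cc1F` is the next variant. Relative to compound 2 the change is 2-fluoro-4-nitrophenyl in place of 3-fluorophenyl on an oxygen on a saturated carbon. Among the compounds with values here, no measured pair carries this change, so no size can be read from the data. The step of an at least 1.6-fold lower number from compound 2 to compound 3 (0.22 log units; that floor lies within the scatter) is expected to move toward stronger inhibition, though the limit of compound 2 leaves its size uncertain. Compound 3 is estimated at 60000 nM, within 8000 nM to 300000 nM.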

Compound 3, half-maximal inhibitory concentration: 30300 nM
Compound 3: middle estimate off by 2.0-fold (0.30 log units), on the high side, and the stated range covers the measured number.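

Going by these compounds alone, the change from 3-fluorophenyl to 2-fluoro-4-nitrophenyl on an oxygen on a saturated carbon gives an at least 3.3-fold lower number from compound 2 to compound 3 (0.51 log units; beyond the scatter) in this assay, the first step between compounds that differ in one place. The size of this step is a floor and not a measured difference, since the entry for compound 2 is a limit: the limit of > 100000 nM in this assay, at which 1 of the 3 values shown sits. Even so, the step shows that the read-out at this position responds to the substituents on a six-membered aromatic ring of carbon, and compound 3 gives a measured number with a group far smaller than the phenoxyphenyl group of compound 1.

The change alters the place of the fluorine and adds the nitro group in a single step, so the step cannot be divided between the two. Open questions are how a 4-nitrophenyl group without fluorine would read in this assay, and whether an amine or a carboxylic acid in the place of the nitro group would give a step in the same direction.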